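Benzyl to Ethyl on Two Amine Scaffolds

The source may report more compounds than this note shows. Statements on the series, on what has been measured and on what is new or still open speak of the compounds shown alone.

Compound 1, `CCN(CCNC(=O)c1cc(Cl)c(N)cc1OC)Cc1ccccc1`: 0.31 mg/kg
Compound 2, `COc1cc(N)c(Cl)cc1C(=O)NCCN(Cc1ccccc1)Cc1ccccc1`: > 30 mg/kg, a limit and not a number
Compound 3, `COc1cc(N)c(Cl)cc1C(=O)NCC1CCCN1Cc1ccccc1`: 1.1 mg/kg

All three measured compounds carry the same amide-bearing core and differ in the amine at the far end of the chain. In a functional assay on the whole organism with Rattus norvegicus as the target (on this read-out lower numbers stand for an effect already at smaller amounts and higher numbers for an effect only at larger amounts of compound), compound 1 gives 0.31 mg/kg. For compound 2 this assay reports only a limit, > 30 mg/kg. Compound 3 gives 1.1 mg/kg in this assay, a higher number than compound 1, and that gap lies beyond the usual scatter.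

From compound 2 to compound 1 the change is methyl in place of phenyl on a saturated chain carbon bound to an amine nitrogen. It gave an at least 96-fold lower number from compound 2 to compound 1 (1.98 log units; beyond the scatter). Only a lower bound of that step is known because compound 2 sits at the limit of > 30 mg/kg in this assay, at which 1 of the 3 values shown sits.

Compound 4, `CCN1CCCC1CNC(=O)c1cc(Cl)c(N)cc1OC`, is not yet measured. It differs from compound 3 by methyl in place of phenyl on a saturated chain carbon bound to an amine nitrogen in a ring. Here the amine nitrogen is in a ring, whereas before it was not, so this is the same kind of change as before, not the same one. How the core of compound 3 differs from that of compound 2 is not broken down here.

Since the earlier change brought an at least 96-fold lower number from compound 2 to compound 1 (1.98 log units; beyond the scatter), a lower number is expected for compound 4 as well, estimated as a 5.5-fold lower number from compound 3 to compound 4 (0.74 log units; beyond the scatter), kept smaller than that bound since the start here is a real number, not a limit. Compound 4 is expected to give about 0.2 mg/kg, most likely between 0.05 mg/kg and 0.8 mg/kg.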

Compound 4, dose for half-maximal effect: > 30 mg/kg
Compound 4 was reported as a limit; the forecaster's own chance of this, stated with the estimate: 5%; at least 150-fold (2.17 log units) between middle value and limit.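

In this assay compound 4 gives > 30 mg/kg, which is a limit and not a number.

On the core of compound 3, the change from benzyl to ethyl gave an at least 27-fold higher number from compound 3 to compound 4 (1.43 log units; beyond the scatter). The change therefore does not carry over from one core to the other in this series, not even in its direction: the same change on two cores in this assay, an at least 96-fold lower number (1.98 log units; beyond the scatter) from compound 2 to compound 1 and an at least 27-fold higher number (1.43 log units; beyond the scatter) from compound 3 to compound 4, at least 2600-fold (3.42 log units) apart, beyond the scatter of two such steps. This pair of steps shows that a result from one core is a poor guide to the other here, but it does not show why the two cores part ways, and two cores set no rule for any further core.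

On these data alone, the true sizes of both steps remain unknown, since each of them ends or starts at a limit: the limit of > 30 mg/kg in this assay, at which 2 of the 4 values shown sit. The compounds shown also leave open whether a methyl or a propyl group on the same amine nitrogen would behave more like ethyl or more like benzyl on either core.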